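The source may report more compounds than this note shows. Statements on the series, on what has been measured and on what is new or still open speak of the compounds shown alone.

Measured compounds:
- compound 1 `O=c1c(CSC(=S)N2CCOCC2)coc2cc(Cl)ccc12`: 6200 nM
- compound 2 `O=c1c(CSC(=S)N2CCCCC2)coc2cc(Cl)ccc12`: 790 nM
- compound 3 `O=c1c(CSC(=S)N2CCCC2)coc2cc(Cl)ccc12`: 7800 nM

In a functional assay on SW480 cells (Homo sapiens) for antiproliferative activity, read by MTT assay, with a stated time of 72 h (on this read-out higher numbers stand for weaker inhibition and lower numbers for stronger inhibition), compound 1 stands second highest of the three numbers; compound 3 is nearest, and compound 2 is furthest. The steps seen so far all sit on the thiocarbonyl carbon: a 7.8-fold lower number from compound 1 to compound 2 (0.89 log units; beyond the scatter), a 1.3-fold higher number from compound 1 to compound 3 (0.10 log units; within the scatter) and a 9.9-fold higher number from compound 2 to compound 3 (0.99 log units; beyond the scatter). Compound 4 `Cc1ccc2c(=O)c(CSC(=S)N3CCOCC3)coc2c1` leaves that part of the molecule untouched and instead changes the ring substituent: methyl in place of chloro on an aromatic carbon. Going by the values given here, none of the measured steps touches that position, so nothing in this assay speaks directly to the exchange of chloro for methyl, and no direction can be read off from the series. Compound 4 is therefore expected to stay close to compound 1, with the step of a 1.0-fold lower number from compound 1 to compound 4 (0.01 log units; within the scatter) estimated as lying within the scatter, though the range has to be kept wide. The expected value for compound 4 in this assay is 6000 nM, between 2000 nM and 20000 nM.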

Compound 4, half-maximal inhibitory concentration: 3800 nM
Compound 4: middle estimate off by 1.6-fold (0.20 log units), on the high side; low and high end bracket the measured number.
By their numbers in this assay, from the lowest: compound 2; then compounds 4, 1 and 3 (each within the scatter of the next, the first and the last beyond it).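

In this assay, methyl in place of chloro on an aromatic carbon gives a 1.6-fold lower number from compound 1 to compound 4 (0.21 log units; within the scatter), the first reading away from the thiocarbonyl carbon. With morpholin-4-yl held fixed, chloro at this position is therefore not needed to keep the activity of compound 1, and methyl serves equally well within the scatter. No supporting data bear on why the two groups read alike.

As far as these compounds go, whether the exchange behaves the same way with piperidin-1-yl on the thiocarbonyl carbon, as in compound 2, remains open. Also open, from the compounds shown here alone, is how this aromatic carbon would respond to groups of a different kind, such as a methoxy, a nitrile, an amine or a carboxylic acid, since only chloro and methyl are in view here.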